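The compounds below may be only part of what the source reports. "The series", "measured", "known", "first", "only" and "open" are said of these compounds alone.

Measured in an ADME assay on CHO cells (Cricetulus griseus) for cytotoxicity, read by MTT assay; a higher number here means a weaker inhibitor, a lower number a stronger inhibitor:
- compound 1, `Cc1cc(C)n(-c2nc(C(F)(F)F)cc(=O)[nH]2)n1`, 150000 nM
- compound 2, `Cc1cc(C2CC2)n(-c2nc(C(F)(F)F)cc(=O)[nH]2)n1`, 78000 nM
- compound 3, `Cc1cc(N)n(-c2nc(C(F)(F)F)cc(=O)[nH]2)n1`, 120000 nM

Compound 2 differs from compound 1 by cyclopropyl in place of methyl on an aromatic carbon, with the step of a 1.9-fold lower number from compound 1 to compound 2 (0.28 log units; within the scatter). Compound 3 differs from compound 1 by amino in place of methyl on an aromatic carbon, with the step of a 1.3-fold lower number from compound 1 to compound 3 (0.10 log units; within the scatter); between compound 2 and compound 3 the step is a 1.5-fold higher number from compound 2 to compound 3 (0.19 log units; within the scatter).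

Compound 4, `Nc1cc(C2CC2)nn1-c1nc(C(F)(F)F)cc(=O)[nH]1`, is not yet measured. It differs from compound 3 by cyclopropyl in place of methyl on an aromatic carbon. This is the same kind of change as that from compound 1 to compound 2, but around the place the surroundings differ: here the carbon is two ring bonds from the ring atom that bears a large group and two ring bonds from the ring atom that bears an amino group, whereas before it was next to the ring atom that bears a large group and two ring bonds from the ring atom that bears a methyl group.

For compound 4 in this assay a step of about a 1.8-fold lower number from compound 3 to compound 4 (0.27 log units; within the scatter) is expected, resting on the earlier step of a 1.9-fold lower number from compound 1 to compound 2 (0.28 log units; within the scatter). Compound 4 is thus estimated at 65000 nM, between 30000 nM and 140000 nM.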

Compound 4, half-maximal inhibitory concentration in the CHO assay: 24000 nM
For compound 4 the middle estimate is 2.7-fold (0.43 log units) above the measured one, and the stated range ends above it.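

In the CHO assay cyclopropyl in place of methyl gives a 5.0-fold lower number from compound 3 to compound 4 (0.70 log units; beyond the scatter), and this step does not differ from the earlier one on the core of compound 1 by more than the scatter allows: the same change on two cores in the CHO assay, a 1.9-fold lower number (0.28 log units; within the scatter) from compound 1 to compound 2 and a 5.0-fold lower number (0.70 log units; beyond the scatter) from compound 3 to compound 4, 2.6-fold (0.41 log units) apart, within the scatter of two such steps. The two steps are therefore compatible with one effect carried between the cores, but this does not show that the effect is the same, as each core offers a single pair and the earlier step lies within the scatter. In a physicochemical assay for solubility, at pH 7.4 (on this read-out lower numbers stand for lower solubility and higher numbers for higher solubility), compound 3 gives 200000 nM and compound 4 gives 10000 nM. The change comes with a large step, but this single pair shows nothing about carrying it to another core: the measured solubility of compound 3, 200000 nM, and of compound 4, 10000 nM, a 20-fold lower number (1.30 log units; beyond the scatter).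

As far as these compounds go, it remains open whether a longer alkyl chain or a carboxylic acid in this place would keep the lower number in the CHO assay without so large a step in the physicochemical assay.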